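Pyridinyl to Cyclopentyl Amide Swap on a Fluorinated Core

A few compounds are considered here, and "the series" means these few. Any claim that something is new, unique, unknown or untested is made for them only; others in the source may bear on it.

Compound 1 `C#CCn1cc(C(=O)NC(CC(=O)Nc2ccccn2)c2ccccc2)c(=O)c2ccc(Cl)nc21` and compound 2 `C#CCn1cc(C(=O)NC(CC(=O)NC2CCCC2)c2ccccc2)c(=O)c2ccc(Cl)nc21` share one core; compound 3 `C#CCn1cc(C(=O)NC(CC(=O)Nc2ccccn2)c2ccccc2)c(=O)c2cc(F)c(Cl)nc21` and the not yet measured compound 4 `C#CCn1cc(C(=O)NC(CC(=O)NC2CCCC2)c2ccccc2)c(=O)c2cc(F)c(Cl)nc21` share another. The two cores differ by fluoro in place of hydrogen on an aromatic carbon. In a functional assay on PA-1 cells (Homo sapiens) for cytotoxicity, read by MTT assay, with a stated time of 72 h (on this read-out lower numbers stand for stronger inhibition and higher numbers for weaker inhibition), compound 1 gives 1700 nM and compound 2 gives 1100 nM. For compound 3 the recorded value is a limit of the assay, > 10000 nM. The change of core brings an at least 5.8-fold higher number from compound 1 to compound 3 (0.76 log units; beyond the scatter). Within the first core, the change cyclopentyl in place of pyridin-2-yl on an amide-type nitrogen brings a 1.5-fold lower number from compound 1 to compound 2 (0.19 log units; within the scatter). The same change, (cyclopentyl in place of pyridin-2-yl on an amide-type nitrogen), takes compound 3 to compound 4. Compound 4 is expected to stay near the limit because a 1.5-fold lower number from compound 1 to compound 2 (0.19 log units; within the scatter) was within the scatter and compound 3 already sits at the limit of > 10000 nM in this assay, at which 1 of the 3 values shown sits, so the expected step is a step that the limit leaves unreadable from compound 3 to compound 4. The estimate for compound 4 is 12000 nM.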

Compound 4, half-maximal inhibitory concentration: 680 nM
Beside the measured number, compound 4's estimate is 18-fold (1.25 log units) above it, and the stated range ends above it.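

In this assay, cyclopentyl in place of pyridin-2-yl on an amide-type nitrogen gives an at least 14-fold lower number from compound 3 to compound 4 (1.16 log units; beyond the scatter), and this step does not carry over unchanged from the other core: the same change on two cores in this assay, a 1.5-fold lower number (0.19 log units; within the scatter) from compound 1 to compound 2 and an at least 14-fold lower number (1.16 log units; beyond the scatter) from compound 3 to compound 4, at least 9.5-fold (0.97 log units) apart, beyond the scatter of two such steps. Fluoro in place of hydrogen on an aromatic carbon likewise behaves differently with cyclopentyl on that nitrogen, where it gives a 1.6-fold lower number from compound 2 to compound 4 (0.21 log units; within the scatter): the same change on two cores in this assay, an at least 5.8-fold higher number (0.76 log units; beyond the scatter) from compound 1 to compound 3 and a 1.6-fold lower number (0.21 log units; within the scatter) from compound 2 to compound 4, at least 9.5-fold (0.97 log units) apart, beyond the scatter of two such steps. Compound 3 is recorded only as a limit of the assay, > 10000 nM; the full size of these gaps therefore cannot be read, and the two pairs do not show how far this holds across the series.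

The compounds shown leave open whether another group on that nitrogen, such as cyclohexyl or phenyl, would follow cyclopentyl or pyridin-2-yl on the two cores. They also do not explain why the two changes depend on each other.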